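The source may report more compounds than this note shows. Statements on the series, on what has been measured and on what is new or still open speak of the compounds shown alone.

Measured compounds in a functional assay on MCF7 cells (Homo sapiens) for inhibition, read by MTT assay; a lower number here means a stronger inhibitor, a higher number a weaker inhibitor:
compound 1 `O=C(CN1CCN(c2ccccc2F)CC1)Nc1ccc(C(=O)/C=C/c2cn(Cc3ccc(Br)cc3)nn2)cc1`: 11300 nM
compound 2 `O=C(CN1CCN(c2ccc([N+](=O)[O-])cc2)CC1)Nc1ccc(C(=O)/C=C/c2cn(Cc3ccc(Br)cc3)nn2)cc1`: 31600 nM
compound 3 `CCCCCCCCCCn1cc(/C=C/C(=O)c2ccc(NC(=O)CN3CCN(c4ccc([N+](=O)[O-])cc4)CC3)cc2)nn1`: 44400 nM

Compound 4 `CCCCCCCCCCn1cc(/C=C/C(=O)c2ccc(NC(=O)CN3CCN(c4ccccc4F)CC3)cc2)nn1` has not yet been measured. It differs from compound 3 by 2-fluorophenyl in place of 4-nitrophenyl on an amine nitrogen in a ring. The same change has already been run once, from compound 2 to compound 1, as 2-fluorophenyl in place of 4-nitrophenyl on an amine nitrogen in a ring, where it gave a 2.8-fold lower number from compound 2 to compound 1 (0.45 log units; beyond the scatter). The cores of compound 2 and compound 3 differ by nonyl in place of 4-bromophenyl on a saturated chain carbon bound to an aromatic nitrogen, a change that gave a 1.4-fold higher number from compound 2 to compound 3 (0.15 log units; within the scatter). The place of the change is the same in both pairs word for word, so the change is the same, applied to a different core. With one precedent only, the step from compound 3 to compound 4 is expected to be about a 2.8-fold lower number from compound 3 to compound 4 (0.44 log units; beyond the scatter), resting on a 2.8-fold lower number from compound 2 to compound 1 (0.45 log units; beyond the scatter). Compound 4 is therefore estimated at 16000 nM, with a range from 7000 nM to 40000 nM.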

Compound 4, half-maximal inhibitory concentration: 40400 nM
For compound 4 the middle estimate is 2.5-fold (0.40 log units) below the measured one; the measured number lies above the stated range.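

In this assay, 2-fluorophenyl in place of 4-nitrophenyl gives a 1.1-fold lower number from compound 3 to compound 4 (0.04 log units; within the scatter), and the two cores cannot be told apart on this change: the same change on two cores in this assay, a 2.8-fold lower number (0.45 log units; beyond the scatter) from compound 2 to compound 1 and a 1.1-fold lower number (0.04 log units; within the scatter) from compound 3 to compound 4, 2.5-fold (0.41 log units) apart, within the scatter of two such steps. Nonyl in place of 4-bromophenyl gives a 3.6-fold higher number from compound 1 to compound 4 (0.55 log units; beyond the scatter), and this change likewise does not separate from its earlier counterpart: the same change on two cores in this assay, a 1.4-fold higher number (0.15 log units; within the scatter) from compound 2 to compound 3 and a 3.6-fold higher number (0.55 log units; beyond the scatter) from compound 1 to compound 4, 2.5-fold (0.41 log units) apart, within the scatter of two such steps. Among these compounds, with only two pairs, and each change falling beyond the scatter on one core and within it on the other, these results show no clear dependence on the core but do not establish that either change carries a fixed size from one core to another.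

Open, going by these compounds, is whether either step would hold with an unsubstituted phenyl on the amine nitrogen in the ring. Also open, on these data alone, is how a shorter chain would behave in place of nonyl on either core.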